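Notes on the step from compound 1 to compound 4

The source may report more compounds than this note shows. Statements on the series, on what has been measured and on what is new or still open speak of the compounds shown alone.

Compound 1 `COc1cc(SC)nc(NC(=S)NC(=O)c2c(-c3ccc(Cl)cc3Cl)noc2C)n1` gives 18.7% in a functional assay on the whole organism for inhibition, with Brassica napus as the target, with a stated time of 72 h, tested at 10 mg/L; on this read-out higher numbers stand for more inhibition of growth at the one concentration tested and lower numbers for less inhibition of growth. Compound 2 `COc1cc(Cl)nc2n/c(=N/C(=O)c3c(-c4ccc(Cl)cc4Cl)noc3C)sn12` gives 28.6% and compound 3 `Cc1onc(-c2ccc(Cl)cc2Cl)c1C(=O)/N=c1/nc2nc(Cl)cc(C)n2s1` gives 20.1%. Compound 1 holds the lowest of the three numbers, but its gaps to compound 3 and to compound 2 both lie within the scatter, so no order among the three can be read. Among the measured compounds shown here, the only measured step, a number 8.5 percentage points lower from compound 2 to compound 3 (within the scatter), also lies within the scatter.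

Compound 4 `Cc1cc(Cl)nc(NC(=S)NC(=O)c2c(-c3ccc(Cl)cc3Cl)noc2C)n1` is not yet measured. It differs from compound 1 as follows: 4-chloro-6-methylpyrimidin-2-yl in place of 4-methoxy-6-(methylsulfanyl)pyrimidin-2-yl on an amide-type nitrogen. For the measured compounds named here, the step from compound 2 to compound 3 touches only part of this change, a methyl entering for a methoxy, and on a different core; it is the one step that bears on it, and it was small. Going by the values given here, the remaining part, chloro in place of methylsulfanyl, has no measured counterpart here. On these data alone, no step beyond the scatter is therefore expected in this assay, and the direction stays open. Compound 4 is estimated at 20%, with a range from 8% to 34%. The implied step, a number 1.3 percentage points higher from compound 1 to compound 4 (within the scatter), is expected to stay within the scatter.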

Compound 4, percent growth inhibition at one concentration: 8.36%
Beside the measured number, compound 4's estimate is 11.6 percentage points above it, within the range that was stated.
By their numbers in this assay, from the lowest: compound 4; then compounds 1, 3 and 2 (each within the scatter of the next).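

In this assay, among the compounds shown here, the change to 4-chloro-6-methylpyrimidin-2-yl in place of 4-methoxy-6-(methylsulfanyl)pyrimidin-2-yl gives a number 10.3 percentage points lower from compound 1 to compound 4 (beyond the scatter) and is the first step to lie beyond the scatter, although it is modest. For the compounds shown here, the read-out therefore does respond to the group on this amide-type nitrogen whose other neighbour is the thiocarbonyl carbon, which the one earlier step, on a different core, did not show. No measurement at hand bears on the reason for this step.

The two parts of the change, chloro in place of methylsulfanyl and methyl in place of methoxy, stay unseparated, as no compound shown carries only one of them. On these data alone, whether a dimethylamino group or a butyl chain on this pyrimidine would shift the number, and in which direction, also stays open.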